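This account rests on a few compounds, and the source may have more. Where it says the series, first, only, none or still open, it means among the compounds named here.

Two members of this series have been measured. Compound 1 `COc1cc(N/C=C\C(=O)c2cn(-c3ccccc3)nc2-c2ccc(Cl)cc2)cc(OC)c1OC` carries a trimethoxyphenyl group on the amine nitrogen; in a functional assay on PC-3 cells (Homo sapiens) for antiproliferative activity, read by MTT assay, with a stated time of 48 h (on this read-out higher numbers stand for weaker inhibition and lower numbers for stronger inhibition), compound 1 gives 9980 nM. Compound 2 `COc1cc(-c2nn(-c3ccccc3)cc2C(=O)/C=C\Nc2ccc(O)cc2)cc(OC)c1OC` instead has a 4-hydroxyphenyl group on that nitrogen, and in this assay compound 2 gives 4600 nM, the lowest of the two numbers; the gap to compound 1 is beyond the scatter. Compound 3 `COc1cc(N/C=C\C(=O)c2cn(-c3ccccc3)nc2-c2cc(OC)c(OC)c(OC)c2)cc(OC)c1OC` has not been measured. It differs from compound 2 in one place: 3,4,5-trimethoxyphenyl in place of 4-hydroxyphenyl on an amine nitrogen. Going by the values given here, no measured pair in this set follows exactly this change, so expectation rests on the two values alone, which suggest that the amine substituent can move the number by an amount just beyond the scatter. The step from compound 2 to compound 3 is expected to be a modest loss, a 1.5-fold higher number from compound 2 to compound 3 (0.18 log units; within the scatter). Compound 3 is therefore expected to give about 7000 nM, somewhere between 2500 nM and 20000 nM.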

Compound 3, half-maximal inhibitory concentration: 14100 nM
Compound 3: middle estimate off by 2.0-fold (0.30 log units), on the low side; the range from low to high includes it.
By their numbers in this assay, from the lowest: compound 2; then compounds 1 and 3 (each within the scatter of the next).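

In this assay, going by these compounds alone, putting 3,4,5-trimethoxyphenyl in place of 4-hydroxyphenyl on the amine nitrogen brings a 3.1-fold higher number from compound 2 to compound 3 (0.49 log units; beyond the scatter) and gives the first single-place reading at this nitrogen, showing that the group held there matters. At the aromatic carbon, 3,4,5-trimethoxyphenyl in place of 4-chlorophenyl brings a 1.4-fold higher number from compound 1 to compound 3 (0.15 log units; within the scatter) and so shows no change that can be told from the scatter, at least with 3,4,5-trimethoxyphenyl on the nitrogen. Nothing available here explains the step at the nitrogen.

The compounds shown cannot separate the effect of losing the hydroxyl group from that of gaining the methoxy groups. A plain phenyl or a 4-methoxyphenyl group on the nitrogen would help to pull those two apart, while a 4-aminophenyl group would test another replacement for the hydroxyl group.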